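This account rests on a few compounds, and the source may have more. Where it says the series, first, only, none or still open, it means among the compounds named here.

Compounds measured in a functional assay on the whole organism (strain Kunming) with Mus musculus as the target, in the formalin test, with a stated time of 0.5 h; a higher number here means that more compound is needed for the effect, a lower number that less compound is needed:
Compound 1 `COc1cc(OC)c(OC)cc1/C=C/COC(=O)/C=C/c1ccc(F)cc1`: 43.4 mg/kg
Compound 2 `COc1cccc(/C=C/C(=O)OC/C=C/c2cc(OC)c(OC)cc2OC)c1`: > 100 mg/kg

Compound 2 has no exact number, only a limit of the assay: > 100 mg/kg. Compound 3 `COc1ccc(/C=C/C(=O)OC/C=C/c2cc(OC)c(OC)cc2OC)cc1` differs from it in one group: 4-methoxyphenyl in place of 3-methoxyphenyl on a double-bonded chain carbon bound to a double-bonded chain carbon. Among the compounds with values here, the only measured step that bears on this change is an at least 2.3-fold higher number from compound 1 to compound 2 (0.36 log units; beyond the scatter), which lies beyond the scatter. That step swapped 4-fluorophenyl for 3-methoxyphenyl, so the group and its number in the name changed together, and the data cannot separate the two. Compound 3 shares the methoxy group with compound 2, but its 4-methoxyphenyl carries the same number as the 4-fluorophenyl of compound 1, which gives 43.4 mg/kg, so a modest move toward a lower number is expected. The expected change is an at least 1.4-fold lower number from compound 2 to compound 3 (0.15 log units; that floor lies within the scatter), an uncertain estimate since it starts from a limit. Compound 3 is estimated at 70 mg/kg, with a range from 30 mg/kg to 160 mg/kg.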

Compound 3, dose for half-maximal effect: 122 mg/kg
Estimate against measurement, compound 3: 1.7-fold (0.24 log units) below, and the stated range covers the measured number.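

In this assay, the earlier step changed the group and its number together, whereas the groups of compound 1 and compound 3 carry the same number in their names, so the swap of fluoro for methoxy on an aromatic carbon now stands alone: it gives a 2.8-fold higher number from compound 1 to compound 3 (0.45 log units; beyond the scatter). Among these compounds, then, the group itself matters, with no change of number needed for the shift. The effect of moving methoxy from 3-methoxyphenyl to 4-methoxyphenyl cannot be read, because compound 2 stands at a limit of the assay rather than at an exact number: the limit of > 100 mg/kg in this assay, at which 1 of the 3 values shown sits.

From the compounds shown here alone, whether the number in the name matters at all therefore stays open. So does whether another group in this place, such as chloro, an amine or a carboxylic acid, would need less compound than fluoro.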